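Antagonist dose in the rat: a sec-butyl swap on two cores

The source may report more compounds than this note shows. Statements on the series, on what has been measured and on what is new or still open speak of the compounds shown alone.

Measured compounds:
Compound 1 `CCCCn1cnc2c(N(C)C)ncnc21`: 10 mg/kg
Compound 2 `CCC(C)n1cnc2c(N(C)C)ncnc21`: 14 mg/kg
Compound 3 `CCCCn1cnc2c(NC3CC3)ncnc21`: 18 mg/kg

In a functional assay on the whole organism for antagonist activity, with Rattus norvegicus as the target (a lower number here means that less compound is needed, a higher number that more compound is needed for the effect), compound 1 gives 10 mg/kg. Compound 2 differs from it by sec-butyl in place of butyl on an aromatic nitrogen, and the step is a 1.4-fold higher number from compound 1 to compound 2 (0.15 log units; within the scatter). Compound 3 differs from compound 1 by cyclopropylamino in place of dimethylamino on an aromatic carbon, with a step of a 1.8-fold higher number from compound 1 to compound 3 (0.26 log units; within the scatter). Compound 4 `CCC(C)n1cnc2c(NC3CC3)ncnc21` has not yet been measured; it differs from compound 3 by sec-butyl in place of butyl on an aromatic nitrogen, the same change in the same place that turns compound 1 into compound 2. Among the compounds with values here, because that change gave a 1.4-fold higher number from compound 1 to compound 2 (0.15 log units; within the scatter), a step of similar size is expected here, a 1.4-fold higher number from compound 3 to compound 4 (0.14 log units; within the scatter), resting on the single earlier pair alone. Compound 4 is therefore estimated at 25 mg/kg, likely between 12 mg/kg and 50 mg/kg.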

Compound 4, dose for half-maximal effect: 13.5 mg/kg
The estimate for compound 4 lay 1.9-fold (0.27 log units) above the measured number; low and high end bracket the measured number.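

In this assay, sec-butyl in place of butyl on an aromatic nitrogen gives a 1.3-fold lower number from compound 3 to compound 4 (0.12 log units; within the scatter), and this does not differ measurably from the same change on the core of compound 1: the same change on two cores in this assay, a 1.4-fold higher number (0.15 log units; within the scatter) from compound 1 to compound 2 and a 1.3-fold lower number (0.12 log units; within the scatter) from compound 3 to compound 4, 1.9-fold (0.27 log units) apart, within the scatter of two such steps. Cyclopropylamino in place of dimethylamino on an aromatic carbon gives a 1.0-fold lower number from compound 2 to compound 4 (0.02 log units; within the scatter), and its two readings also agree within the scatter: the same change on two cores in this assay, a 1.8-fold higher number (0.26 log units; within the scatter) from compound 1 to compound 3 and a 1.0-fold lower number (0.02 log units; within the scatter) from compound 2 to compound 4, 1.9-fold (0.27 log units) apart, within the scatter of two such steps. Neither change is thus shown to depend on the core, but every step here lies within the scatter, so the agreement shows neither a real effect of either change nor that a real effect would carry over.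

Still open, on these data alone, is whether a longer chain such as hexyl on the aromatic nitrogen would move the dose beyond the scatter. The same holds for a piperidine in place of dimethylamino on the aromatic carbon.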